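Fluoro to chloro on one aromatic carbon

The source may hold more compounds than are shown below. What is called first, only, known or untested is meant among the compounds shown, and "the series" means these compounds.

Among the compounds with values here, in a functional assay on NCI-H460 cells (Homo sapiens) for cytotoxicity, read by MTT assay, with a stated time of 68 h (a lower number here means a stronger inhibitor, a higher number a weaker inhibitor), compound 3 (`O=C(Nc1cccc(-c2ccccc2F)c1)C(Cl)Cl`) gives the highest actual number so far (26800 nM). The nearest neighbour is compound 1 (`O=C(Nc1cccc(-c2ccccc2C(F)(F)F)c1)C(Cl)Cl`) at 7550 nM. Compound 2 (`O=C(Nc1cccc(-c2cccc(F)c2)c1)C(Cl)Cl`) reads > 50000 nM as a limit of the assay, not a number. Compound 4 (`O=C(Nc1cccc(-c2ccccc2Cl)c1)C(Cl)Cl`) has chloro in place of fluoro on an aromatic carbon. Within the data shown here, only one measured step touches this place, and it is modest: fluoro in place of trifluoromethyl (a 3.5-fold higher number from compound 1 to compound 3 (0.55 log units; beyond the scatter)). Read backwards, that step suggests that leaving fluoro may lower the number, though chloro itself is untested here. A modest step downward is therefore expected (a 2.2-fold lower number from compound 3 to compound 4 (0.35 log units; beyond the scatter)). For compound 4 the estimate is 12000 nM (expected range 5000 nM to 35000 nM).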

Compound 4, half-maximal inhibitory concentration: > 50000 nM
Compound 4: a limit, no number; the forecaster's own chance of this, stated with the estimate: 10%; middle value at least 4.1-fold (0.61 log units) from the limit.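

Replacing trifluoromethyl with chloro on this aromatic carbon is not a neutral swap: an at least 6.6-fold higher number from compound 1 to compound 4 (0.82 log units; beyond the scatter). Against fluoro the result is less clear, since the reading gives only an at least 1.8-fold higher number from compound 3 to compound 4 (0.27 log units; that floor lies within the scatter), so chloro cannot be firmly separated from fluoro at this position. Compound 4 sits at a limit of the assay, not a number: the limit of > 50000 nM in this assay, at which 2 of the 4 values shown sit.

On these data alone, the true size of both steps therefore stays open. As far as these compounds go, it also remains open what an amine or a methoxy group on this same carbon would give.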